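The source may hold more compounds than are shown below. What is called first, only, known or untested is meant among the compounds shown, and "the series" means these compounds.

Compound 1 `CCCCCCCCNc1nccnc1C(=O)NCc1ccccc1` carries an octyl chain on the ring nitrogen of the same core as compound 2 `CCCCNc1nccnc1C(=O)NCc1ccccc1`, which carries a butyl chain. In an ADME assay on HeLa cells (Homo sapiens) for cytotoxicity, read by microscopy, with a stated time of 6 days (a higher number here means that more compound is tolerated, a lower number that less compound is tolerated), compound 1 reaches only the limit of the assay, > 100000 nM. In this assay compound 2 likewise reaches only the limit, > 100000 nM. The step that the two limits leave unreadable from compound 2 to compound 1 is therefore not readable, since the limit of > 100000 nM in this assay, at which 3 of the 3 values shown sit, holds for every value shown. Compound 3 `CCCCNc1cncc(C(=O)NCc2ccccc2)n1` has the same atoms as compound 2 joined differently; the difference between the two cores is not broken down here. In this assay compound 3 also gives only the limit, > 100000 nM. Compound 4 `CCCCCCCCNc1cncc(C(=O)NCc2ccccc2)n1` differs from compound 3 by butyl in place of hydrogen on a saturated chain carbon, four bonds along the chain from a nitrogen on an aromatic ring, the same change as butyl in place of hydrogen on a saturated chain carbon, four bonds along the chain from a nitrogen on an aromatic ring. Because the limit of > 100000 nM in this assay, at which 3 of the 3 values shown sit, covers all three values, compound 4 is expected to sit near that limit as well, a step of about a number no higher from compound 3 to compound 4 (the limit leaves the size open). The estimate for compound 4 is 100000 nM, between 30000 nM and 300000 nM.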

Compound 4, minimum cytotoxic concentration: > 100000 nM
Compound 4: a limit, no number (the forecaster's own chance of this, stated with the estimate: 70%); the middle value lies on the limit itself.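

Compound 3 and compound 4 both give only a limit in this assay, so the step between them cannot be read. The compounds shown leave open at what concentration any of them becomes cytotoxic, and whether chain length or core arrangement alters that.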